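Turning the hydroxy of compound 1 into methoxy

The source may hold more compounds than are shown below. What is called first, only, known or untested is meant among the compounds shown, and "the series" means these compounds.

Going by the values given here, in a functional assay on MKN-28 cells (Homo sapiens) for cytotoxicity, read by MTT assay (a lower number here means a stronger inhibitor, a higher number a weaker inhibitor), compound 1 `C=C1C(=O)[C@]23C[C@@]1(O)CC[C@H]2[C@@]12C=CC(=O)[C@](C)(C(=O)O1)[C@H]2[C@@H]3C(=O)OC` gives 39600 nM as the highest number of the three compounds measured so far. Compound 2 `C=C1C(=O)[C@]23C[C@@]1(O)CC[C@H]2[C@@]12C=CC(=O)[C@](C)(C(=O)O1)[C@H]2[C@@H]3C(=O)OCc1ccccc1` reads 2500 nM here and compound 3 `C=C1C(=O)[C@]23C[C@@]1(I)CC[C@H]2[C@@]12C=CC(=O)[C@](C)(C(=O)O1)[C@H]2[C@@H]3C(=O)OCc1ccccc1` reads 3000 nM here. Compound 4 `C=C1C(=O)[C@]23C[C@@]1(OC)CC[C@H]2[C@@]12C=CC(=O)[C@](C)(C(=O)O1)[C@H]2[C@@H]3C(=O)OC` keeps the core of compound 1 and differs by a single change methyl in place of hydrogen on an oxygen on a saturated carbon that turns hydroxy into methoxy, with methyl in place of hydrogen on an oxygen on a saturated carbon. The large step of a 16-fold lower number from compound 1 to compound 2 (1.20 log units; beyond the scatter) lies at another place in the molecule and says little about this change. The closer guide is the step of a 1.2-fold higher number from compound 2 to compound 3 (0.08 log units; within the scatter) for iodo in place of hydroxy on a saturated ring carbon, and it stays within the scatter. Among the compounds with values here, that is only one pair, and no methoxy compound has been measured yet. A step beyond the scatter is therefore not expected in this assay for this change. The expected step is a 1.1-fold lower number from compound 1 to compound 4 (0.05 log units; within the scatter) and would stay within the scatter. Compound 4 is estimated at 35000 nM with an expected range from 15000 nM to 70000 nM in this measurement.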

Compound 4, half-maximal inhibitory concentration: 3400 nM
Compound 4: the middle estimate sits 10-fold (1.01 log units) above what was measured; the measured number lies below the stated range.
By their numbers in this assay, from the lowest: compounds 2, 3 and 4 (each within the scatter of the next); then compound 1.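

In this assay this oxygen on a saturated carbon proves sensitive: capping it with a methyl gives a 12-fold lower number from compound 1 to compound 4 (1.07 log units; beyond the scatter) and so a large change from one added carbon. The only earlier change at this place, a 1.2-fold higher number from compound 2 to compound 3 (0.08 log units; within the scatter), had shown nothing beyond the scatter, but it was a swap to iodo made on compound 2, which carries the phenyl, so the outcome of a change here depends on the group that enters, the rest of the molecule, or both. Nothing available explains why the methyl has so large an effect.

As far as these compounds go, what an ethoxy or an amine would do on this carbon remains open. So does whether methoxy and the phenyl of compound 2 would together lower the number further, or whether the two changes overlap.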